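Aryl swap on the fused core: compound 1 to compound 3

The compounds below may be only part of what the source reports. "The series", "measured", "known", "first", "only" and "open" are said of these compounds alone.

compound 1 `COc1ccc2cc(C(C)c3nnc4n3N=C(c3ccc(Cl)cc3Cl)CS4)ccc2c1` — 14600 nM
compound 2 `CC(C)Cc1ccc(C(C)c2nnc3n2N=C(c2ccc(Cl)cc2Cl)CS3)cc1` — 11800 nM

In a functional assay on MCF7 cells (Homo sapiens) for inhibition, read by sulforhodamine B assay, with a stated time of 72 h (on this read-out higher numbers stand for weaker inhibition and lower numbers for stronger inhibition), compound 1 gives 14600 nM, and compound 2 gives 11800 nM. Compound 1 has the highest of the two numbers; compound 2 is nearest, and the gap between the two lies within the scatter, so they are not told apart on this read-out. Compound 3 `COc1ccc2cc(C(C)c3nnc4n3N=C(c3ccc(C)cc3)CS4)ccc2c1` is the next member and has not yet been measured. It differs from compound 1 in one place: 4-methylphenyl in place of 2,4-dichlorophenyl on a carbon with a double bond to nitrogen. For the measured compounds named here, no measured pair shows this exchange, so its effect has no precedent within the set. Both measured compounds carry the 2,4-dichlorophenyl group, and the only variation seen so far, between compound 1 and compound 2, spans less than the scatter. The step of a 1.2-fold higher number from compound 1 to compound 3 (0.09 log units; within the scatter) is therefore expected to be small, with no direction that can be called beyond the scatter, and the uncertainty is wide. Compound 3 is estimated at 18000 nM, with a range from 6000 nM to 60000 nM.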

Compound 3, half-maximal inhibitory concentration: 11000 nM
The estimate for compound 3 lay 1.6-fold (0.21 log units) above the measured number; the measured number falls inside the stated range.
By their numbers in this assay, from the lowest: compounds 3, 2 and 1 (each within the scatter of the next).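

For the compounds shown here, exchanging 2,4-dichlorophenyl for 4-methylphenyl on the carbon with a double bond to nitrogen gives the first direct reading at this position: in this assay the step is a 1.3-fold lower number from compound 1 to compound 3 (0.12 log units; within the scatter) and does not separate the two compounds. Going by these compounds alone, on the core of compound 1, both chlorine atoms can therefore leave and a methyl group can enter without a difference beyond the scatter, which also shows that this aryl position is not limited to the 2,4-dichlorophenyl group carried by the earlier compounds. Nothing available bears on why this single exchange leaves the read-out within the scatter.

As far as these compounds go, whether this tolerance extends beyond these two aryl groups remains open, since both are carbon-only aromatic rings without hydrogen-bond donors or acceptors, and an aryl ring carrying an amine or a carboxylic acid, or a longer alkyl chain in place of the ring, would test the position more sharply. Also open, from the compounds shown here alone, is whether the same exchange behaves alike on the core of compound 2, as the present reading comes from one pair alone.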